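The source may report more compounds than this note shows. Statements on the series, on what has been measured and on what is new or still open speak of the compounds shown alone.

Measured in an assay on CHO cells for displacement of a labelled ligand from adenosine receptor A1 (Homo sapiens), read by scintillation counting, with a stated time of 120 min, tested at 10 uM; on this read-out lower numbers stand for less inhibition and higher numbers for more inhibition at the one concentration tested (going by the name of the read-out):

Compound 1 `COc1ccc(N2CCN(Cc3csc(N)c3C(=O)c3ccc(Cl)cc3)CC2)cc1`: 0%
Compound 2 `Nc1scc(CN2CCN(C3CCCCCC3)CC2)c1C(=O)c1ccc(Cl)cc1`: 0%
Compound 3 `Nc1scc(CN2CCN(c3cccc(F)c3)CC2)c1C(=O)c1ccc(Cl)cc1`: 1%

Compound 3 is the closest measured neighbour of the next compound. Its numbers sit with the other two: the step of a number 1 percentage points higher from compound 1 to compound 3 (within the scatter) and the step of a number 1 percentage points higher from compound 2 to compound 3 (within the scatter) both stay inside the scatter, and the step of no change at the digits printed from compound 1 to compound 2 (within the scatter) does likewise, so none of the three compounds shows inhibition that can be told from zero at the concentration tested.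

Compound 4 `Nc1scc(CN2CCN(c3cccc(Cl)c3)CC2)c1C(=O)c1ccc(Cl)cc1` is to be measured. It differs from compound 3 by chloro in place of fluoro on an aromatic carbon. For the measured compounds named here, no measured step touches this position: the three measured steps all exchange the whole group on the amine nitrogen in the ring, and every one of them, whether to a 4-methoxyphenyl, a cycloheptyl or a 3-fluorophenyl, left the number inside the scatter. With no shift seen for changes of that size, a single exchange of fluoro for chloro on the 3-fluorophenyl is expected to change nothing beyond the scatter, so the expected step is a number 1 percentage points higher from compound 3 to compound 4 (within the scatter). Compound 4 is therefore estimated at 2%, with a range from 0% to 12%.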

Compound 4, a percentage reported as inhibition, at one concentration (the size of the read-out at that concentration, not a potency): 0%
Beside the measured number, compound 4's estimate is 2 percentage points above it, within the range that was stated.
By their numbers in this assay, from the lowest: compounds 1, 2, 4 and 3 (each within the scatter of the next).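

In this assay, the aromatic carbon meta to a large group now has a step of its own: a number 1 percentage points lower from compound 3 to compound 4 (within the scatter), so chloro in place of fluoro is not told from no change at the one concentration tested. The 3-chlorophenyl group also joins the other groups on the amine nitrogen without leaving the scatter, with no change at the digits printed from compound 2 to compound 4 (within the scatter) and no change at the digits printed from compound 1 to compound 4 (within the scatter), so the flat reading now holds for a substituent exchange on the aromatic ring as well as for exchanges of the whole group. No supporting data bear on this result.

As far as these compounds go, what a nitrile or a carboxylic acid would do on that aromatic carbon stays open. Also open, from the compounds shown here alone, is whether a longer chain on the amine nitrogen, or a change in the shared core, would give inhibition beyond the scatter in this assay.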